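Swapping a Phenyl for a Pyridine in a Cytotoxicity Series

The compounds below may be only part of what the source reports. "The series", "measured", "known", "first", "only" and "open" are said of these compounds alone.

Of the compounds shown here, two sharing one core have been measured in a functional assay on MCF7 cells (Homo sapiens) for cytotoxicity, read by sulforhodamine B assay, with a stated time of 72 h; on this read-out lower numbers stand for stronger inhibition and higher numbers for weaker inhibition. Compound 1 `CCS(=O)(=O)Nc1cc(-c2ccc3ncnc(Nc4ccc(OC)cc4)c3c2)cnc1OC` gives 1790 nM, the lowest of the two numbers on hand. Compound 2 `CCCCS(=O)(=O)Nc1cc(-c2ccc3ncnc(Nc4cccc(C(=O)OCC)c4)c3c2)cnc1OC` gives 36400 nM, a value far above that of compound 1, and the gap between these two lies beyond the usual scatter. Among the measured compounds shown here, compound 2 differs from compound 1 in more than one place, so no single step between them is drawn here; only the two values stand side by side.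

Compound 3 `CCS(=O)(=O)Nc1cc(-c2ccc3ncnc(Nc4ccc(OC)nc4)c3c2)cnc1OC` has not yet been measured. It differs from compound 1 in one place: 6-methoxypyridin-3-yl in place of 4-methoxyphenyl on a nitrogen on an aromatic ring. The change keeps the methoxy and the size of the group, exchanging a ring carbon for a ring nitrogen. Nothing in the two measured compounds isolates what such a swap does, so the expectation rests on compound 1 alone and on the modest size of the change. The step in this assay is expected to be small, a 1.2-fold higher number from compound 1 to compound 3 (0.09 log units; within the scatter), with no firm direction and most likely within the scatter. On that basis compound 3 is estimated at 2200 nM, with a likely range from 600 nM to 8000 nM.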

Compound 3, half-maximal inhibitory concentration: 3770 nM
For compound 3 the middle estimate is 1.7-fold (0.23 log units) below the measured one, and the stated range covers the measured number.
By their numbers in this assay, from the lowest: compound 1; then compound 3; then compound 2.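

In this assay, among the compounds shown here, this is the first comparison that changes only one place. With the methoxy and the heavy-atom count unchanged, 6-methoxypyridin-3-yl in place of 4-methoxyphenyl on the nitrogen gives a 2.1-fold higher number from compound 1 to compound 3 (0.32 log units; beyond the scatter), so exchanging one ring carbon for a ring nitrogen in this group is enough to move the number beyond the scatter. The step is modest and runs towards weaker inhibition, which shows that this position accepts a pyridine ring with only a limited loss, while the count of hydrogen-bond acceptors in the group rises by one. No measurement on hand explains why the number rises, so the step stands as an observation without a cause.

What the compounds shown leave open is how this position responds when the methoxy itself is replaced, for example by an amine, a carboxylic acid or a longer chain such as ethoxy. Compound 2 differs from compound 1 and compound 3 in more than one place, so its number cannot be tied to any single group.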